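A Trifluoromethyl Group Replaces Methoxy on Compound 3

The source may report more compounds than this note shows. Statements on the series, on what has been measured and on what is new or still open speak of the compounds shown alone.

Three compounds share one core. Compound 1 `OCCCCC#Cc1ccccc1C#Cc1ccccc1` gives 5220 nM in a functional assay on DU-145 cells (Homo sapiens) for cytotoxicity; a higher number here means a weaker inhibitor of growth, a lower number a stronger inhibitor of growth. Compound 2 `COc1ccccc1C#Cc1ccccc1C#CCCCCO` gives 14300 nM in this assay, and compound 3 `COc1cccc(C#Cc2ccccc2C#CCCCCO)c1` gives 4100 nM. Compound 3 gives the lowest of the three numbers, though its gap to compound 1 is within the scatter and nothing separates the two; only compound 2 stands apart from it. Both measured steps put a methoxy in place of hydrogen: a 2.7-fold higher number from compound 1 to compound 2 (0.44 log units; beyond the scatter) and a 1.3-fold lower number from compound 1 to compound 3 (0.10 log units; within the scatter).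

Compound 4 `OCCCCC#Cc1ccccc1C#Cc1cccc(C(F)(F)F)c1` differs from compound 3 in one place: trifluoromethyl in place of methoxy on an aromatic carbon. Among the compounds with values here, no measured step removes a methoxy or brings in a trifluoromethyl, so no step bears directly on this change. On these data alone, what the numbers do show is that a 1.3-fold lower number from compound 1 to compound 3 (0.10 log units; within the scatter), so the methoxy at this position made no difference beyond the scatter against hydrogen, and its loss is unlikely to matter much; what the trifluoromethyl contributes is unknown. The expectation is therefore a step of no size beyond the scatter in this assay, with a wide range to allow for the unknown group. Compound 4 is estimated at 4500 nM, from 1500 nM to 14000 nM, which means an expected step of a 1.1-fold higher number from compound 3 to compound 4 (0.04 log units; within the scatter).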

Compound 4, concentration for 50% growth inhibition: 15300 nM
For compound 4 the middle estimate is 3.4-fold (0.53 log units) below the measured one; measured number above the stated range.
By their numbers in this assay, from the lowest: compounds 3 and 1 (each within the scatter of the next); then compounds 2 and 4 (each within the scatter of the next).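

This position does not accept every group equally. In this assay trifluoromethyl in place of methoxy gives a 3.7-fold higher number from compound 3 to compound 4 (0.57 log units; beyond the scatter) and trifluoromethyl in place of hydrogen gives a 2.9-fold higher number from compound 1 to compound 4 (0.47 log units; beyond the scatter) and so both steps, though modest, point the same way, towards weaker inhibition of growth. The second step matters most, since methoxy on this same aromatic carbon, meta to a large group, made no difference beyond the scatter against hydrogen, so the higher number of compound 4 cannot be read as the mere loss of methoxy and goes with the arrival of trifluoromethyl. Nothing in the data shown explains why this group behaves differently from methoxy here.

On these data alone, it remains open whether the weaker inhibition is particular to trifluoromethyl or would also appear with chlorine, a nitrile, an amine or a carboxylic acid on this carbon. As far as these compounds go, it is also open whether trifluoromethyl would give a step of like size on another carbon of the same six-membered aromatic ring.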